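Cytotoxicity of caffeate-linked diphenyl ethers in U-937 cells

This account rests on a few compounds, and the source may have more. Where it says the series, first, only, none or still open, it means among the compounds named here.

Measured so far:
compound 1, `O=C(/C=C/c1ccc(O)c(O)c1)OCCCCCCCCOc1cc(Cl)ccc1Oc1ccc(Cl)cc1Cl` — 40200 nM
compound 2, `O=C(/C=C/c1ccc(O)c(O)c1)OCCCCCCCCCCCCOc1cc(Cl)ccc1Oc1ccc(Cl)cc1Cl` — 174000 nM
compound 3, `O=C(/C=C/c1ccc(O)c(O)c1)OCCCOc1cc(Cl)ccc1Oc1ccc(Cl)cc1Cl` — > 392000 nM

The three compounds share a catechol cinnamate ester joined through an alkyl chain to a chlorinated diphenyl ether, and they were examined in an ADME assay on U-937 cells (Homo sapiens) for cytotoxicity, read by MTT assay, with a stated time of 72 h; on this read-out higher numbers stand for lower toxicity in this test and lower numbers for higher toxicity in this test. In this assay compound 1 gives 40200 nM. Compound 2, which carries the longer chain, gives 174000 nM. For compound 3 the result is a limit of the assay, > 392000 nM, so only a range is known; it sits where the test stops, as the evidence records (the limit of > 392000 nM in this assay, at which 1 of the 3 values shown sits).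

The step under study leads from compound 3 to compound 4, `COc1ccc(/C=C/C(=O)OCCCOc2cc(Cl)ccc2Oc2ccc(Cl)cc2Cl)cc1OC`. The change is 3,4-dimethoxyphenyl in place of 3,4-dihydroxyphenyl on a double-bonded chain carbon bound to a double-bonded chain carbon. Among the compounds with values here, no measured step among the three compounds is available to calibrate this change; no compound in the set has a 3,4-dimethoxyphenyl group.

Compound 3 already stands at the limit, so the expected step from compound 3 to compound 4 is an at least 1.1-fold lower number from compound 3 to compound 4 (0.04 log units; that floor lies within the scatter), which amounts to no change beyond the scatter. Compound 4 is therefore estimated to give 350000 nM, within a range from 100000 nM to 700000 nM, with a fair chance that the assay again reports only a limit.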

Compound 4, concentration lethal to 50% of the cells: > 371000 nM
Compound 4: a limit, no number (the forecaster's own chance of this, stated with the estimate: 55%); middle value at least 1.0-fold (0.02 log units) from the limit.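

Within the data shown here, compound 3 and compound 4 both end at a limit of the test, so no step between them can be read. The compounds shown leave open whether 3,4-dimethoxyphenyl in place of 3,4-dihydroxyphenyl changes the result in this assay at all, or what it would do with the longer chains of compound 1 and compound 2.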